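The source may report more compounds than this note shows. Statements on the series, on what has been measured and on what is new or still open speak of the compounds shown alone.

Compound 1 `CCOC(=O)c1c(-c2ccc(OC)c(OC)c2)csc1N` gives 100% in an assay on isolated protein for inhibition of protein kinase C zeta type (Homo sapiens), with stated times of 1 h and 2.5 min, tested at 30 uM; a lower number here means less inhibition, a higher number more inhibition at the concentration tested (going by the name of the read-out).
Compound 2 `CCOC(=O)c1c(-c2ccc(C)cc2)csc1N` gives 80% in this assay.
Compound 3 `CCOC(=O)c1c(-c2ccc(OC)cc2)csc1N` gives 100% in this assay.

Compound 3 stands level with compound 1, the two together giving the highest numbers of the three, while compound 2 lies below them. The step of no change at the digits printed from compound 1 to compound 3 (within the scatter) shows that losing one methoxy group from the aryl ring left the read-out unchanged, whereas a number 20 percentage points higher from compound 2 to compound 3 (beyond the scatter) shows a modest gain on exchanging methyl for methoxy. Compound 4 `CCOC(=O)c1c(-c2ccc(OC)cc2F)csc1N` has not yet been measured. It differs from compound 3 in that (fluoro in place of hydrogen on an aromatic carbon). For the measured compounds named here, no measured step involves a fluoro group, so the two known steps bear on this change only in showing that substituents on this ring shift the read-out by little or by a modest amount. Since compound 3 already gives 100%, there is little room for an upward step; the expected step in this assay is a number 10 percentage points lower from compound 3 to compound 4 (within the scatter), none beyond the scatter or a small downward one. Compound 4 is therefore expected to give 90%, with a range of 70% to 100%.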

Compound 4, a percentage reported as inhibition, at one concentration (the size of the read-out at that concentration, not a potency): 100%
Beside the measured number, compound 4's estimate is 10 percentage points below it; the range from low to high includes it.
By their numbers in this assay, from the lowest: compound 2; then compounds 1, 3 and 4 (each within the scatter of the next).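

Fluoro in place of hydrogen, on an aromatic carbon ortho to a large group and meta to a methoxy group, gives no change at the digits printed from compound 3 to compound 4 (within the scatter) in this assay, so a substituent at this position, which none of the earlier compounds carries, costs nothing beyond the scatter here. Compound 4 at 100% shares its printed value with compound 3 at 100%, and a single tested concentration at this level cannot separate the two in potency. No supporting measurement is available to explain this result.

The compounds shown leave open whether a larger group on this same carbon, such as chlorine, a methoxy group or an amine, would also hold the read-out. They also leave open whether fluoro would leave the number unchanged on the methyl-bearing ring of compound 2, whose 80% lies lower.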